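Clearance notes: aryl swap on the shared core

The source may hold more compounds than are shown below. What is called first, only, known or untested is meant among the compounds shown, and "the series" means these compounds.

Measured so far in an ADME assay (liver) for metabolic stability, with Liver microsome (Homo sapiens) as the target, using microsomes and NADPH, with a stated time of 30 min, tested at 1 uM; a higher number here means faster removal of the compound, a lower number slower removal:
compound 1 `CC(C)(C)n1cc(-c2cc(C(O)(C(F)(F)F)C(F)(F)F)cnc2N2CCN(S(=O)(=O)c3ccc(N)nc3)CC2)cn1`: 86 mL.min-1.g-1
compound 2 `Nc1ccc(S(=O)(=O)N2CCN(c3ncc(C(O)(C(F)(F)F)C(F)(F)F)cc3-c3cccnc3)CC2)cn1`: 17 mL.min-1.g-1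

Compound 2 holds the lowest of the two numbers in this assay; the nearest is compound 1, a step away of a 5.1-fold lower number from compound 1 to compound 2 (0.70 log units; beyond the scatter). Compound 3 `Nc1ccc(S(=O)(=O)N2CCN(c3ncc(C(O)(C(F)(F)F)C(F)(F)F)cc3-c3cc4ccccc4s3)CC2)cn1` differs from compound 2 in one place: 1-benzothiophen-2-yl in place of pyridin-3-yl on an aromatic carbon. Within the data shown here, the single measured step bears on it only loosely, showing that the number moves when the group on that carbon is exchanged, yet it does not cover 1-benzothiophen-2-yl. A step upward beyond the scatter is nonetheless expected for compound 3, about a 3.5-fold higher number from compound 2 to compound 3 (0.55 log units; beyond the scatter), with wide uncertainty. Compound 3 is estimated at 60 mL.min-1.g-1, in the range 25 mL.min-1.g-1 to 150 mL.min-1.g-1.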

Compound 3, intrinsic clearance in microsomes: < 14 mL.min-1.g-1
Compound 3 was reported as a limit; the forecaster's own chance of this, stated with the estimate: 5%; middle value at least 4.2-fold (0.63 log units) away from the limit.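

Compound 3 stands at a limit of this assay, not at a number: the limit of < 14 mL.min-1.g-1 in this assay, at which 1 of the 3 values shown sits.

Taken as a floor, the change from pyridin-3-yl to 1-benzothiophen-2-yl gives an at least 1.2-fold lower number from compound 2 to compound 3 (0.08 log units; that floor lies within the scatter), so how far the two compounds actually differ cannot be read. Even so, this carbon accepts a larger group with no ring nitrogen without returning to the high clearance of compound 1, with an at least 6.1-fold lower number from compound 1 to compound 3 (0.78 log units; beyond the scatter).

Still open, going by these compounds, is whether the tert-butyl group or the pyrazole ring carries the clearance of compound 1. On these data alone, how a plain phenyl or a saturated ring such as piperidine would read at this carbon also remains open.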